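From 4-nitrophenyl to pyridin-2-yl on a shared core

The source may report more compounds than this note shows. Statements on the series, on what has been measured and on what is new or still open speak of the compounds shown alone.

Compounds measured in a functional assay on SW-620 cells (Homo sapiens) for antiproliferative activity, read by MTT assay, with a stated time of 24 h; on this read-out lower numbers stand for stronger inhibition and higher numbers for weaker inhibition:
compound 1 `COc1cccc(/C=C/C(=O)c2ccc(OC)c3c2OC(C)(C)C=C3)c1`: > 10000 nM
compound 2 `COc1ccc(C(=O)/C=C/c2ccc([N+](=O)[O-])cc2)c2c1C=CC(C)(C)O2`: 3520 nM

Compound 1 has the entry > 10000 nM, which is a limit of this assay and not a number. In this assay, going by the values given here, compound 2 gives 3520 nM, the only true number so far. The next compound, compound 3 `COc1ccc(C(=O)/C=C/c2ccccn2)c2c1C=CC(C)(C)O2`, keeps the shared core and changes the group on a double-bonded chain carbon bound to a double-bonded chain carbon: pyridin-2-yl in place of 4-nitrophenyl on a double-bonded chain carbon bound to a double-bonded chain carbon. In words, it carries pyridin-2-yl in place of 4-nitrophenyl.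

Among the compounds with values here, one measured step bears on this place, an at least 2.8-fold lower number from compound 1 to compound 2 (0.45 log units; beyond the scatter), where 4-nitrophenyl replaced 3-methoxyphenyl. For compound 1 that size is only a bound because of the limit of > 10000 nM in this assay, at which 1 of the 2 values shown sits. Within the data shown here, no measured compound yet carries pyridin-2-yl, so the evidence is thin. Given an at least 2.8-fold lower number from compound 1 to compound 2 (0.45 log units; beyond the scatter), removing 4-nitrophenyl is expected to raise the number in this assay by a modest step, and a result at the limit would not be surprising. The expected change is a 1.7-fold higher number from compound 2 to compound 3 (0.23 log units; within the scatter). Compound 3 is estimated at 6000 nM, with an expected range of 2500 nM to 14000 nM.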

Compound 3, half-maximal inhibitory concentration: 5000 nM
Compound 3: the middle estimate sits 1.2-fold (0.08 log units) above what was measured, within the range that was stated.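

At this place, on a double-bonded chain carbon bound to a double-bonded chain carbon, this assay gives a 1.4-fold higher number from compound 2 to compound 3 (0.15 log units; within the scatter), so the two compounds cannot be told apart. The earlier compounds had shown only that 4-nitrophenyl and 3-methoxyphenyl differ here; this pair shows that 4-nitrophenyl can give way to pyridin-2-yl, a six-membered aromatic ring with 1 hetero atom and no nitro group, without a change beyond the scatter. The other new step is an at least 2.0-fold lower number from compound 1 to compound 3 (0.30 log units; that floor lies within the scatter), and it stays only a floor that does not clear the scatter, because compound 1 stands at a limit and not at a number: the limit of > 10000 nM in this assay, at which 1 of the 3 values shown sits.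

The compounds shown leave open whether the ring nitrogen of pyridin-2-yl matters at this place, which pyridin-3-yl or pyridin-4-yl could test, and whether an amine or a carboxylic acid on the phenyl ring would move the number beyond the scatter in either direction. They also leave open whether the match between 4-nitrophenyl and pyridin-2-yl would hold on a different core.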